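The source may report more compounds than this note shows. Statements on the series, on what has been measured and on what is new or still open speak of the compounds shown alone.

Among the measured compounds shown here, compound 2 `CC1=CC[C@H](C(C)(C)NC(=S)N/N=C/c2ccccc2Cl)CC1` is the only member of the series with a number in a functional assay on MCF7 cells (Homo sapiens) for inhibition, read by sulforhodamine B assay, with a stated time of 48 h; on this read-out lower numbers stand for stronger inhibition of growth and higher numbers for weaker inhibition of growth: compound 2 gives 11000 nM. Compound 1 `CC1=CC[C@H](C(C)(C)NC(=S)N/N=C/c2ccc(F)cc2)CC1` gives only a limit, > 100000 nM, namely (the limit of > 100000 nM in this assay, at which 1 of the 2 values shown sits). For the measured compounds named here, the single measured step, an at least 9.0-fold lower number from compound 1 to compound 2 (0.95 log units; beyond the scatter), already shows that swapping the aromatic group on that carbon moves the read-out beyond the scatter. Compound 3 `CC1=CC[C@H](C(C)(C)NC(=S)N/N=C/c2ccco2)CC1` differs from compound 2 by furan-2-yl in place of 2-chlorophenyl on a carbon with a double bond to nitrogen. Another swap of the aromatic group is therefore expected to shift the number, with the direction uncertain. For compound 3 the estimate is 30000 nM, in the range 7000 nM to 120000 nM. The expected step is a 2.7-fold higher number from compound 2 to compound 3 (0.44 log units; beyond the scatter).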

Compound 3, concentration for 50% growth inhibition: 9300 nM
Estimate against measurement, compound 3: 3.2-fold (0.51 log units) above; the measured number falls inside the stated range.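

In this assay, furan-2-yl in place of 2-chlorophenyl on this carbon changes nothing that can be told from the scatter: a 1.2-fold lower number from compound 2 to compound 3 (0.07 log units; within the scatter). The gain over 4-fluorophenyl is therefore not tied to 2-chlorophenyl alone, since a five-membered aromatic ring with 1 hetero atom also gives it: an at least 10-fold lower number from compound 1 to compound 3 (1.03 log units; beyond the scatter). That step rests on a limit of the assay held by compound 1, not a number: the limit of > 100000 nM in this assay, at which 1 of the 3 values shown sits.

Open, going by these compounds, is how plain phenyl, pyridin-2-yl or an aminophenyl group would read at this carbon. Also open, on these data alone, is whether any change elsewhere on the core moves the number.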